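The source may report more compounds than this note shows. Statements on the series, on what has been measured and on what is new or still open speak of the compounds shown alone.

Measured in an ADME assay on Vero 76 cells (Chlorocebus sabaeus) for cytotoxicity, read by crystal violet staining, with a stated time of 96 h; a higher number here means that more compound is tolerated, a lower number that less compound is tolerated:
- compound 1 `FC(F)(F)c1cccc(NC(=S)Nc2ccccc2)c1`: 39000 nM
- compound 2 `CCNC(=S)Nc1cccc(C(F)(F)F)c1`: > 100000 nM (a limit of the assay, not a number)
- compound 3 `O=C(NC(=S)Nc1cccc(C(F)(F)F)c1)[C@H]1C[C@@H]2CC[C@H]1C2`: 20000 nM

Compound 3 gives 20000 nM, within the scatter of compound 1 at 39000 nM. Compound 2 reads > 100000 nM, which is a limit and not a number.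

The next structure is compound 4 `CC(=O)NC(=S)Nc1cccc(C(F)(F)F)c1`. The change is one carbon atom in place of a group of 7 heavy atoms (7 carbon; 2 five-membered non-aromatic rings of carbon only), on a carbonyl carbon, so one carbon atom replaces the group carrying the 2 five-membered non-aromatic rings of carbon only.

Among the measured compounds shown here, only one measured step bears on this, and only loosely: an at least 2.5-fold higher number from compound 1 to compound 2 (0.40 log units; beyond the scatter). That step also removes a ring-bearing group, but it puts ethyl in place of phenyl on an amide-type nitrogen, not on a carbonyl carbon. With that single precedent from compound 2 at > 100000 nM, a rise in this assay is expected, of moderate size and with low confidence. The expected change is a 2.8-fold higher number from compound 3 to compound 4 (0.44 log units; beyond the scatter), a modest rise that could still fall back into the scatter. The top of the range is set by the limit of > 100000 nM in this assay, at which 1 of the 3 values shown sits.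

For compound 4 the estimated half-maximal cytotoxic concentration is 55000 nM, with an expected range from 22000 nM to 100000 nM.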

Compound 4, half-maximal cytotoxic concentration: > 100000 nM
Compound 4: only a limit was reported; the forecaster's own chance of this, stated with the estimate: 30%; at least 1.8-fold (0.25 log units) between middle value and limit.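

In this assay, methyl in place of the group carrying the 2 five-membered non-aromatic rings of carbon only, on the carbonyl carbon, gives an at least 5.0-fold higher number from compound 3 to compound 4 (0.69 log units; beyond the scatter), so the ring-bearing group and not the carbonyl itself goes with the lower number in this pair. Compound 4 reads > 100000 nM, which is a limit of the assay, so a carbonyl on the amide-type nitrogen does not by itself bring a measurable cytotoxic concentration into the tested range. Acetyl in place of phenyl gives an at least 2.5-fold higher number from compound 1 to compound 4 (0.40 log units; beyond the scatter), the same direction as ethyl in place of phenyl, an at least 2.5-fold higher number from compound 1 to compound 2 (0.40 log units; beyond the scatter), and among the four compounds shown the two with a second ring-bearing group, compound 1 and compound 3, are the two that give numbers, with none going against this.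

Whether acetyl or ethyl tolerates more cannot be read, because compound 2 and compound 4 both stand at the assay's limit: the limit of > 100000 nM in this assay, at which 2 of the 4 values shown sit. Where the number starts to fall between methyl and the ring-bearing group on the carbonyl carbon stays open, and a tert-butyl, a cyclopropyl or a longer chain there, or a terminal amine or carboxylic acid, would mark that point.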